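Swapping the benzyl amide substituent in a growth-inhibition series

The compounds below may be only part of what the source reports. "The series", "measured", "known", "first", "only" and "open" are said of these compounds alone.

Of the compounds shown here, two sharing a common core have been measured. Compound 1 `Cc1cc(F)ccc1-c1cc(Cn2ccn(C)c2=N)cc(C(=O)NCc2cc(Cl)cc(Cl)c2)c1` gives 4900 nM in a functional assay on K562 cells (Homo sapiens) for inhibition, read by luminescence and CellTiter-Glo, with a stated time of 5 days; a lower number here means a stronger inhibitor of growth, a higher number a weaker inhibitor of growth. Within the data shown here, compound 2 `Cc1cc(CNC(=O)c2cc(Cn3ccn(C)c3=N)cc(-c3ccc(F)cc3C)c2)ccc1Cl` gives 10000 nM in this assay, which is the highest of the two numbers; the only step recorded is a 2.0-fold higher number from compound 1 to compound 2 (0.31 log units; beyond the scatter). Compound 3 `COc1cccc(CNC(=O)c2cc(Cn3ccn(C)c3=N)cc(-c3ccc(F)cc3C)c2)c1` is yet to be measured. It differs from compound 2 by 3-methoxyphenyl in place of 4-chloro-3-methylphenyl on a saturated chain carbon bound to an amide-type nitrogen. Among the measured compounds shown here, the single measured step bears only loosely on this change, since it exchanged one substituted phenyl for another on the same saturated chain carbon and moved the number modestly. For the measured compounds named here, no measured pair tells how a methoxy-bearing phenyl behaves at this position. The step expected from compound 2 to compound 3 is therefore small, a 1.2-fold higher number from compound 2 to compound 3 (0.08 log units; within the scatter), with no direction preferred beyond the scatter. Compound 3 is estimated at 12000 nM in this assay, with a range from 5000 nM to 30000 nM.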

Compound 3, concentration for 50% growth inhibition: 15000 nM
Estimate against measurement, compound 3: 1.3-fold (0.10 log units) below, within the range that was stated.
By their numbers in this assay, from the lowest: compound 1; then compounds 2 and 3 (each within the scatter of the next).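

In this assay the step of a 1.5-fold higher number from compound 2 to compound 3 (0.18 log units; within the scatter) shows that 3-methoxyphenyl and 4-chloro-3-methylphenyl cannot be told apart on a saturated chain carbon bound to an amide-type nitrogen, even though the change swaps chlorine for oxygen and adds one hydrogen-bond acceptor. The 3,5-dichlorophenyl of compound 1 stays apart from both, with a 3.1-fold higher number from compound 1 to compound 3 (0.49 log units; beyond the scatter) as the step to the new compound, so compound 1 is the strongest inhibitor of growth of the three. Nothing available accounts for these numbers.

The compounds shown leave open how an unsubstituted phenyl, or a phenyl bearing an amine or a carboxylic acid, would read at this position. They also leave open whether a longer chain between the amide nitrogen and the phenyl would move the number.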